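Swapping the Butyl Chain for an Imidazole Ring

This account rests on a few compounds, and the source may have more. Where it says the series, first, only, none or still open, it means among the compounds named here.

Compound 1, `CCCCc1ccc(C(=O)/C=C/c2ccc([N+](=O)[O-])s2)cc1`: 81300 nM
Compound 2, `O=C(/C=C/c1ccc([N+](=O)[O-])o1)c1ccc(-c2ccccc2)cc1`: > 100000 nM
Compound 3, `O=C(/C=C/c1ccc([N+](=O)[O-])o1)c1ccc(N2CCCCC2)cc1`: 349000 nM

Of the compounds shown here, three with a shared core have been tested in an ADME assay on Vero cells (Chlorocebus sabaeus) for cytotoxicity, read by resazurin assay, with a stated time of 72 h; a lower number here means that less compound is tolerated, a higher number that more compound is tolerated. Compound 1 gives 81300 nM, the lowest of the two numbers available, so it is the least tolerated of the measured set. Compound 3 gives 349000 nM, a gap from compound 1 that lies beyond the usual scatter. Compound 2 gives > 100000 nM, which is a limit of this assay and not a number. For the measured compounds named here, because of the limit of > 100000 nM in this assay, at which 1 of the 3 values shown sits, the step that the limit leaves unreadable from compound 2 to compound 3 cannot be read, so no measured step on this core has a known size.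

Compound 4, `O=C(/C=C/c1ccc([N+](=O)[O-])s1)c1ccc(-n2ccnc2)cc1`, differs from compound 1 in one place: 1H-imidazol-1-yl in place of butyl on an aromatic carbon. Going by the values given here, no measured step exchanges butyl for 1H-imidazol-1-yl, and the single step between measured compounds, from compound 2 to compound 3, touches a different group and is unreadable. The expectation for compound 4 therefore rests on the spread of the measured set alone. Compound 4 is expected to sit between compound 1 and compound 3, with the step of a 1.8-fold higher number from compound 1 to compound 4 (0.27 log units; within the scatter) expected to run toward more tolerated but with wide uncertainty. Compound 4 is estimated at 150000 nM, within a range from 50000 nM to 400000 nM.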

Compound 4, half-maximal cytotoxic concentration: 42700 nM
Compound 4: the middle estimate sits 3.5-fold (0.55 log units) above what was measured, outside the stated range (below it).
By their numbers in this assay, from the lowest: compounds 4 and 1 (each within the scatter of the next); then compound 3.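

In this assay, for the compounds shown here, putting 1H-imidazol-1-yl in place of butyl gives a 1.9-fold lower number from compound 1 to compound 4 (0.28 log units; within the scatter) and is the first step on this shared core whose size can be read. The position is on an aromatic carbon of a six-membered aromatic ring of carbon only, para to a large group, and the change there swaps a chain with no ring and no hydrogen-bond acceptors for a five-membered aromatic ring with 2 hetero atoms and 2 hydrogen-bond acceptors, yet the two numbers stay within the scatter of each other, so this large change in the group's make-up brings no readable shift in tolerance. Going by these compounds alone, the only earlier step cannot be read, which leaves this pair as the sole measured comparison of its kind: the limit of > 100000 nM in this assay, at which 1 of the 4 values shown sits.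

Going by these compounds, whether a carboxylic acid, a morpholine ring or a chain longer than butyl at the same position would also stay within the scatter of compound 1 remains open. Also open, on these data alone, is whether 1H-imidazol-1-yl would behave the same way on the core of compound 2, and no cause for the result can be drawn from these compounds.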